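Bromo to fluoro on the arylidene ring of compound 2

A few compounds are considered here, and "the series" means these few. Any claim that something is new, unique, unknown or untested is made for them only; others in the source may bear on it.

Measured compounds:
compound 1, `COc1ccc(-c2cc(/N=C3/NC(=O)CS3)cs2)cc1`, > 50000 nM
compound 2, `O=C1N/C(=N/c2csc(-c3ccc(Cl)cc3)c2)S/C1=C\c1ccc(Br)cc1`, 3300 nM

The two measured compounds were tested in a functional assay on HCT-116 cells (Homo sapiens) for cytotoxicity, read by MTT assay, with a stated time of 72 h; a lower number here means a stronger inhibitor, a higher number a weaker inhibitor. Compound 1, `COc1ccc(-c2cc(/N=C3/NC(=O)CS3)cs2)cc1`, gives only a limit there: > 50000 nM is the limit of the assay and not a number. Among the measured compounds shown here, compound 2, `O=C1N/C(=N/c2csc(-c3ccc(Cl)cc3)c2)S/C1=C\c1ccc(Br)cc1`, gives 3300 nM in this assay and is the only compound with a numerical value. The other result shown belongs to compound 1 and is the one the evidence the limit of > 50000 nM in this assay, at which 1 of the 2 values shown sits, records.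

Compound 3, `O=C1N/C(=N/c2csc(-c3ccc(Cl)cc3)c2)S/C1=C\c1ccc(F)cc1`, has not yet been measured. It differs from compound 2 in one place: fluoro in place of bromo on an aromatic carbon. No step between two measured compounds describes a change of this kind, so the size of the step in this assay cannot be read from the data shown. A halogen swap at that position is expected to move the value by a modest amount, if at all, and a small loss is thought somewhat more likely than a gain. For compound 3 the estimate is 6000 nM, with a range from 2000 nM to 20000 nM, a step of a 1.8-fold higher number from compound 2 to compound 3 (0.26 log units; within the scatter) that is expected to stay close to the scatter.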

Compound 3, half-maximal inhibitory concentration: 7400 nM
Beside the measured number, compound 3's estimate is 1.2-fold (0.09 log units) below it, and the stated range covers the measured number.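

Fluoro in place of bromo gives the first step that can be read at this position: in this assay, the change from 4-bromophenyl to 4-fluorophenyl is a 2.2-fold higher number from compound 2 to compound 3 (0.35 log units; beyond the scatter). The halogen on this ring therefore has a modest but real bearing on the value, and the step lies beyond the usual scatter. Compound 3 still gives a numerical value, 7400 nM, but nothing measured here accounts for the step.

As far as these compounds go, with only bromo and fluoro compared at this place, the data do not show whether the trend would extend to other groups, and how an amine, a nitrile or a carboxylic acid on the same aromatic carbon would compare remains open. Among the compounds shown here, compound 1, whose > 50000 nM is a limit of the assay and not a number, differs from compound 2 and compound 3 in more than one place, so no step to or from it can be read, and the contribution of the arylidene ring as a whole stays unresolved.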